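Cytotoxicity notes: nitro substitution on the central ring

The compounds below may be only part of what the source reports. "The series", "measured", "known", "first", "only" and "open" are said of these compounds alone.

Of the compounds shown here, three with the shared core have been measured. In a functional assay on HepG2 cells (Homo sapiens) for cytotoxicity, read by MTT assay, with a stated time of 48 h (a higher number here means a weaker inhibitor, a lower number a stronger inhibitor), compound 1 `COc1cc(-c2nc3ccc([N+](=O)[O-])cc3[nH]2)cc(-c2nc3ccc([N+](=O)[O-])cc3[nH]2)c1` gives 8900 nM. Compound 2 `Brc1ccc2nc(-c3cccc(-c4nc5ccc(Br)cc5[nH]4)c3)[nH]c2c1` gives 12100 nM in this assay. Compound 3 `FC(F)(F)c1ccc2nc(-c3cccc(-c4nc5ccc(C(F)(F)F)cc5[nH]4)c3)[nH]c2c1` gives 6600 nM in this assay, the lowest of the three numbers, although its gaps to compound 1 and to compound 2 both lie within the scatter, so no order among the three is claimed. Compound 4 `O=[N+]([O-])c1cc(-c2nc3ccc(C(F)(F)F)cc3[nH]2)cc(-c2nc3ccc(C(F)(F)F)cc3[nH]2)c1` differs from compound 3 by nitro in place of hydrogen on an aromatic carbon. Going by the values given here, no step between measured compounds isolates this change, so the expected step in this assay is none beyond the scatter, in either direction. Compound 4 is estimated at 6500 nM, with a range from 3000 nM to 14000 nM. The expected step of a 1.0-fold lower number from compound 3 to compound 4 (0.01 log units; within the scatter) stays within the scatter.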

Compound 4, half-maximal inhibitory concentration: 4100 nM
For compound 4 the middle estimate is 1.6-fold (0.20 log units) above the measured one; low and high end bracket the measured number.
By their numbers in this assay, from the lowest: compounds 4, 3, 1 and 2 (each within the scatter of the next, the first and the last beyond it).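

Nitro in place of hydrogen, on an aromatic carbon meta to two large groups, is the first change in the series that can be read on its own. In this assay it gives a 1.6-fold lower number from compound 3 to compound 4 (0.21 log units; within the scatter) and so stays within the scatter, which shows that this position takes nitro without a step beyond it. No measurement here bears on the reason for this result.

Open, from the compounds shown here alone, is whether an amine or a carboxylic acid in the same place would give a step beyond the scatter. Also open, going by these compounds, is whether nitro gives a similar step on compound 2.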